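Dichlorophenyl for Trifluoromethylphenyl: Expected Cytotoxicity of Compound 4

This account rests on a few compounds, and the source may have more. Where it says the series, first, only, none or still open, it means among the compounds named here.

Among the measured compounds shown here, compound 1 `O=C1c2ccccc2C(=O)N1CCOC(=S)N(C(=O)c1ccc(C(F)(F)F)cc1)c1ccc(Cl)cc1` is the only member of this small set with a numerical read-out: in an ADME assay on MT4 cells (Homo sapiens) for cytotoxicity, read by MTT assay (on this read-out higher numbers stand for lower toxicity in this test and lower numbers for higher toxicity in this test), compound 1 gives 10000 nM. Compound 2 `Cc1ccc(N(C(=O)c2ccccc2C)C(=S)OCCN2C(=O)c3ccccc3C2=O)cc1` reaches only a limit of the assay, giving > 100000 nM. Compound 3 `Cc1ccc(N(C(=O)c2cccc(C)c2)C(=S)OCCN2C(=O)c3ccccc3C2=O)cc1` likewise sits at a limit, with > 100000 nM. The step that the two limits leave unreadable from compound 2 to compound 3 can therefore not be read. The ceiling concerned is the limit of > 100000 nM in this assay, at which 2 of the 3 values shown sit. Compound 4 `O=C1c2ccccc2C(=O)N1CCOC(=S)N(C(=O)c1c(Cl)cccc1Cl)c1ccc(Cl)cc1` differs from compound 1 by 2,6-dichlorophenyl in place of 4-(trifluoromethyl)phenyl on a carbonyl carbon. For the measured compounds named here, no measured step mirrors this change, so the measured steps supply no expected size in this assay in either direction. Compound 4 is estimated at 30000 nM, within 8000 nM to 100000 nM, which would mean an expected step of a 3.0-fold higher number from compound 1 to compound 4 (0.48 log units; beyond the scatter), close to the scatter.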

Compound 4, half-maximal cytotoxic concentration: 20000 nM
Beside the measured number, compound 4's estimate is 1.5-fold (0.18 log units) above it; low and high end bracket the measured number.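

In this assay, among the compounds shown here, the exchange of 4-(trifluoromethyl)phenyl for 2,6-dichlorophenyl on a carbonyl carbon gives the first readable step in this set, which reads a 2.0-fold higher number from compound 1 to compound 4 (0.30 log units; within the scatter) and so stays inside the usual scatter of repeats. At this position, then, one substituted phenyl gives way to another without a separable difference in the read-out. Compound 2 and compound 3 offer no such reading, each standing at a limit and not at a number: the limit of > 100000 nM in this assay, at which 2 of the 4 values shown sit.

Open, on these data alone, is whether an amine or a carboxylic acid on this phenyl ring would give a step beyond the scatter. As far as these compounds go, a longer chain in place of the ring also remains open.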